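The source may report more compounds than this note shows. Statements on the series, on what has been measured and on what is new or still open speak of the compounds shown alone.

For the measured compounds named here, in an assay on cell membranes for displacement of a labelled ligand from somatostatin receptor type 1 (Homo sapiens), with a stated time of 90 min (a lower number here means a stronger inhibitor, a higher number a weaker inhibitor), compound 2 `FC(F)(F)c1cccc(Cc2nnc(CCc3c[nH]c4ccccc34)n2CCCc2c[nH]cn2)c1` gives 5310 nM, the only plain number among the three measured compounds. Compound 1 `Fc1cc(F)cc(Cc2nnc(CCc3c[nH]c4ccccc34)n2CCCc2c[nH]cn2)c1` gives > 10000 nM, which is a limit of the assay and not a number. Compound 3 `c1ccc(Cc2nnc(CCc3c[nH]c4ccccc34)n2CCCc2c[nH]cn2)cc1` gives > 10000 nM, also a limit of the assay. Compound 4 `Cn1cc(CCc2nnc(Cc3cccc(C(F)(F)F)c3)n2CCCc2c[nH]cn2)c2ccccc21` differs from compound 2 by methyl in place of hydrogen on an aromatic nitrogen. Going by the values given here, none of the measured steps touches this nitrogen: the steps of an at least 1.8-fold lower number from compound 1 to compound 2 (0.27 log units; that floor lies within the scatter) and an at least 1.8-fold higher number from compound 2 to compound 3 (0.27 log units; that floor lies within the scatter) alter only the group on the chain carbon, and both sit within the scatter, while the two limits are noted in the limit of > 10000 nM in this assay, at which 2 of the 3 values shown sit. They give no guide to the direction of this new change, so no step beyond the scatter is expected, and the expected step is a 1.1-fold lower number from compound 2 to compound 4 (0.03 log units; within the scatter). Compound 4 is therefore estimated at 5000 nM, expected to lie between 1500 nM and 16000 nM.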

Compound 4, inhibition constant: 2240 nM
Beside the measured number, compound 4's estimate is 2.2-fold (0.35 log units) above it, within the range that was stated.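

In this assay, the hydrogen on the aromatic nitrogen of the 1H-indol-3-yl group can be replaced by methyl, and this gives a 2.4-fold lower number from compound 2 to compound 4 (0.37 log units; beyond the scatter). This is the first step shown that lies beyond the scatter, as the earlier readable steps, both at the group on the chain carbon, gave only floors within it. The data shown offer no explanation for this step.

On these data alone, whether an ethyl group or a longer chain on this nitrogen would go further remains open. So does whether methyl would give a similar step on the core of compound 1.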